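The source may report more compounds than this note shows. Statements on the series, on what has been measured and on what is new or still open speak of the compounds shown alone.

Measured so far in a functional assay on HeLa cells (Homo sapiens) for cytotoxicity, read by MTT assay, with a stated time of 72 h, tested at 3 uM; a lower number here means less inhibition of growth, a higher number more inhibition of growth at the concentration tested:

compound 1 `Cc1cccc(/C(N)=N/NC(=S)N2CCCCC2)n1`: 68.9%
compound 2 `Cc1cccc(/C(N)=N/NC(=S)N2CCCC2)n1`: 56.8%
compound 3 `Cc1ccnc(/C(N)=N/NC(=S)N2CCCCC2)c1`: 23.9%

Compound 1 and compound 2 share a core and differ only in the change (pyrrolidin-1-yl in place of piperidin-1-yl on a thiocarbonyl carbon). That change gave the step of a number 12.1 percentage points lower from compound 1 to compound 2 (beyond the scatter). Compound 3 carries the same atoms as compound 1 joined differently; the difference between the two cores is not broken down here. Compound 3 stands lowest of the three measured numbers, beyond the scatter from both compound 1 and compound 2.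

Compound 4 `Cc1ccnc(/C(N)=N/NC(=S)N2CCCC2)c1` is not yet measured. It differs from compound 3 by pyrrolidin-1-yl in place of piperidin-1-yl on a thiocarbonyl carbon, which is the same kind of change as that from compound 1 to compound 2, and the place lines of the two changes read the same. If the change behaves on the core of compound 3 as it did on the core of compound 1, the expected step in this assay is a number 9.9 percentage points lower from compound 3 to compound 4 (within the scatter), set beside a number 12.1 percentage points lower from compound 1 to compound 2 (beyond the scatter); the low starting point of compound 3 leaves little room downward, so the step is expected somewhat smaller. For compound 4 the expected value is 14%, likely between 2% and 28%.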

Compound 4, percent growth inhibition at one concentration: 52.1%
Estimate against measurement, compound 4: 38.1 percentage points below; measured number above the stated range.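

In this assay, pyrrolidin-1-yl in place of piperidin-1-yl on a thiocarbonyl carbon gave a number 28.2 percentage points higher from compound 3 to compound 4 (beyond the scatter). The change therefore does not carry from one core to the other in either direction or size: the same change on two cores in this assay, a number 12.1 percentage points lower (beyond the scatter) from compound 1 to compound 2 and a number 28.2 percentage points higher (beyond the scatter) from compound 3 to compound 4, 40.3 percentage points apart, beyond the scatter of two such steps. Among these compounds, this shows that the outcome of the change depends on the core it is made on, but with only two cores it does not show which feature of the cores is responsible, and it gives no rule for predicting the step on a third core.

Going by these compounds, it remains open whether other cyclic or open-chain amines on the thiocarbonyl carbon, such as morpholin-4-yl or dimethylamino, would follow the core of compound 1 or the core of compound 3. Also open, on these data alone, is whether the opposite steps would persist across a range of concentrations, since each number in this assay comes from a single concentration.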